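This account rests on a few compounds, and the source may have more. Where it says the series, first, only, none or still open, it means among the compounds named here.

Compounds measured so far:
compound 1, `COc1cc2c(/C=C3/C(=O)Nc4ccc(Cl)cc43)c(Cl)n(Cc3cc(OC)c(OC)c(OC)c3)c2cc1C`: 2090 nM
compound 2, `COc1cc2c(/C=C3/C(=O)Nc4cccc(Cl)c43)c(Cl)n(Cc3cc(OC)c(OC)c(OC)c3)c2cc1C`: 2950 nM

Both numbers come from a functional assay on cells (Cancer cell lines, Homo sapiens) for cytotoxicity, with a stated time of 48 h; on this read-out lower numbers stand for stronger inhibition of growth and higher numbers for weaker inhibition of growth. Compound 1 holds the lowest of the two numbers, yet its nearest neighbour lies within the scatter: a 1.4-fold higher number from compound 1 to compound 2 (0.15 log units; within the scatter), so the two compounds cannot be told apart on this read-out.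

Compound 3, `COc1ccc2c(c1)/C(=C\c1c(Cl)n(Cc3cc(OC)c(OC)c(OC)c3)c3cc(C)c(OC)cc13)C(=O)N2`, is built from compound 1 by one change: methoxy in place of chloro on an aromatic carbon. Among the measured compounds shown here, the only step measured so far, from compound 1 to compound 2, swaps one chloro-bearing ring pair for another and produces no change beyond the scatter. No measured step exchanges chloro for methoxy, so the direction of this particular change is not shown by the data at hand. With a neighbouring change of this size leaving the number unmoved, the reasonable expectation is no shift beyond the scatter, with a wide margin for surprise in either direction.

Compound 3 is therefore expected to give about 2500 nM in this assay, within 800 nM to 8000 nM, which amounts to an estimated step of a 1.2-fold higher number from compound 1 to compound 3 (0.08 log units; within the scatter).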

Compound 3, concentration for 50% growth inhibition: 10200 nM
Compound 3: middle estimate off by 4.1-fold (0.61 log units), on the low side, outside the stated range (above it).
By their numbers in this assay, from the lowest: compounds 1 and 2 (each within the scatter of the next); then compound 3.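

In this assay, methoxy in place of chloro on this aromatic carbon gives a 4.9-fold higher number from compound 1 to compound 3 (0.69 log units; beyond the scatter), so this exchange weakens growth inhibition. The earlier comparison, a 1.4-fold higher number from compound 1 to compound 2 (0.15 log units; within the scatter), showed no readable difference between two chloro-bearing groups, whereas this result shows that the number can respond to what sits on this carbon, meta to a fused ring and para to a fused ring. Nothing available explains why the number rises with this exchange.

A single exchange between two groups leaves open how the number would respond to other groups on this carbon, such as fluoro, an amine, a hydroxyl group, or ethoxy, a longer chain than methoxy, and so whether chloro is unusually favourable or methoxy unusually unfavourable here. Going by these compounds, it is also open whether the same exchange would raise the number to a similar extent at other aromatic carbons of the shared core, or in the other cell-based tests that would be needed to show how general this result is.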